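A Sulfonyl Swap on a Urea Core

This account rests on a few compounds, and the source may have more. Where it says the series, first, only, none or still open, it means among the compounds named here.

Compound 1 `CCN(CC)S(=O)(=O)NC(=O)Nc1c(C(C)C)cccc1C(C)C` is a urea whose sulfonyl carries a diethylamino group. In an assay on liver for inhibition of sterol O-acyltransferase 1 (Rattus norvegicus), using microsomes (a higher number here means a weaker inhibitor, a lower number a stronger inhibitor), compound 1 gives 2500 nM. Compound 2 `CC(C)c1cccc(C(C)C)c1NC(=O)NS(=O)(=O)NC(c1ccccc1)c1ccccc1` shares the same core; in this assay compound 2 gives 4100 nM. Compound 1 has the lower of the two numbers, but the gap between them lies within the scatter of repeated measurements, so the two cannot be put in order on this evidence.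

Compound 3 `CCCCCCC(C)OS(=O)(=O)NC(=O)Nc1c(C(C)C)cccc1C(C)C` has not yet been measured. It differs from compound 1 in one place: (1-methylheptyl)oxy in place of diethylamino on a sulfonyl sulfur. For the measured compounds named here, no measured pair shows what such a change does here, so nothing points to a large shift in either direction. The expected step is a 1.1-fold lower number from compound 1 to compound 3 (0.06 log units; within the scatter), which stays within the scatter. Compound 3 is estimated at 2200 nM, with a likely range from 600 nM to 8000 nM.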

Compound 3, half-maximal inhibitory concentration: 35000 nM
Beside the measured number, compound 3's estimate is 16-fold (1.20 log units) below it; the measured number lies above the stated range.
By their numbers in this assay, from the lowest: compounds 1 and 2 (each within the scatter of the next); then compound 3.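

In this assay putting (1-methylheptyl)oxy in place of diethylamino on a sulfonyl sulfur brings a 14-fold higher number from compound 1 to compound 3 (1.15 log units; beyond the scatter) and so gives the first measured sign that this position responds strongly to what sits on it. The swap alters two things at once, since oxygen replaces nitrogen as the atom joined to the sulfur and the entering group has more heavy atoms, so the step cannot be assigned to either change alone. Nothing available gives a reason for the step.

A small group such as ethoxy would keep the oxygen without the long chain, while (1-methylheptyl)amino would keep the chain with nitrogen in place of oxygen, and these compounds include neither. Also open, on these data alone, is how a sulfonyl sulfur carrying a cyclic amine such as piperidine would compare.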